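The source may report more compounds than this note shows. Statements on the series, on what has been measured and on what is new or still open speak of the compounds shown alone.

Measured so far:
- compound 1 `COc1ccc(/C=C/C(=O)c2ccccc2-c2cccc(F)c2)cc1`: 640 nM
- compound 2 `COc1ccc(/C=C/C(=O)c2ccccc2-c2cccc(F)c2)cc1OC`: 1200 nM
- compound 3 `O=C(/C=C/c1ccccc1-c1ccc(F)cc1)c1cccc(O)c1`: 9300 nM

All three were run in a functional assay on MCF7 cells (Homo sapiens) for antiproliferative activity, read by sulforhodamine B assay, with a stated time of 48 h; a lower number here means a stronger inhibitor, a higher number a weaker inhibitor. Compound 3 gives the highest number of the three; the gap to compound 2 and to compound 1 lies beyond the scatter in both cases. The difference between the core of compound 3 and the core of compound 1 is not broken down here.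

Compound 4 `COc1ccc(C(=O)/C=C/c2ccccc2-c2ccc(F)cc2)cc1O` is still to be measured. It arises from compound 3 by methoxy in place of hydrogen on an aromatic carbon. The same kind of change has been made once already, from compound 1 to compound 2: methoxy in place of hydrogen on an aromatic carbon. The surroundings differ, though: in compound 2 the new group sits ortho to a methoxy group and meta to a large group, whereas in compound 4 it sits ortho to a hydroxy group and para to a large group. That earlier step gave a 1.9-fold higher number from compound 1 to compound 2 (0.27 log units; within the scatter).

The expectation for compound 4 rests on that single precedent, because a 1.9-fold higher number from compound 1 to compound 2 (0.27 log units; within the scatter) was small. A step of a 1.4-fold higher number from compound 3 to compound 4 (0.15 log units; within the scatter) is therefore expected, with wide uncertainty given the changed surroundings. Compound 4 is estimated at 13000 nM, between 5000 nM and 35000 nM.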

Compound 4, half-maximal inhibitory concentration: 560 nM
For compound 4 the middle estimate is 23-fold (1.37 log units) above the measured one; measured number outside the range, below it.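

In this assay, methoxy in place of hydrogen on an aromatic carbon gives a 17-fold lower number from compound 3 to compound 4 (1.22 log units; beyond the scatter), a large step that lifts the core of compound 3 out of its position as the highest number in the series. The size of this step does not carry over from the core of compound 1, so the earlier step is no guide to this change on another core in this series: the same change on two cores in this assay, a 1.9-fold higher number (0.27 log units; within the scatter) from compound 1 to compound 2 and a 17-fold lower number (1.22 log units; beyond the scatter) from compound 3 to compound 4, 31-fold (1.49 log units) apart, beyond the scatter of two such steps. Among the compounds shown here, this shows that the outcome depends on the surroundings, but it does not show which difference matters: there are only two pairs, the cores differ in more than one place, and in compound 4 the methoxy sits ortho to a hydroxy group and para to a large group.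

The compounds shown leave open whether the step on the core of compound 3 depends on that hydroxy group. They also leave open whether an ethoxy group, a chlorine or an amine in the same place would behave like methoxy.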